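Compound 1 to compound 3: a 2-methoxyethoxy addition

The compounds below may be only part of what the source reports. "The series", "measured", "known", "first", "only" and "open" are said of these compounds alone.

Measured in a physicochemical assay for solubility, using the shake flask method, measured as kinetic solubility, with a stated time of 2 h, at pH 7.4; a lower number here means a less soluble compound, a higher number a more soluble compound:
- compound 1 `CN(Cc1ccc(F)cc1)c1cc(C(=O)Nc2ccccc2)ncn1`: < 5000 nM (a limit, not a number)
- compound 2 `CN(Cc1ccc(S(C)(=O)=O)cc1)c1cc(C(=O)Nc2ccccc2)ncn1`: 10000 nM

Compound 1 is known only as a limit, (the limit of < 5000 nM in this assay, at which 1 of the 2 values shown sits). Compound 3 `COCCOc1ccc(NC(=O)c2cc(N(C)Cc3ccc(F)cc3)ncn2)cc1` differs from it as follows: 2-methoxyethoxy in place of hydrogen on an aromatic carbon. Within the data shown here, the sole measured step, an at least 2.0-fold higher number from compound 1 to compound 2 (0.30 log units; that floor lies within the scatter), swaps a different group at a different site, so it gives only a weak guide. No step beyond the scatter is expected in this assay, and no firm direction. Compound 3 is expected at 5000 nM, with an estimated range from 1500 nM to 15000 nM. The estimated step is a number no lower from compound 1 to compound 3 (the limit leaves the size open).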

Compound 3, solubility: < 5000 nM
Compound 3 gave a limit, no number; the forecaster's own chance of this, stated with the estimate: 40%; the middle value sits exactly at the limit.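

Compound 1 and compound 3 both stand only as limits, so no step between them can be read: the limit of < 5000 nM in this assay, at which 2 of the 3 values shown sit.

As far as these compounds go, what 2-methoxyethoxy in place of hydrogen does to the number in this assay stays open, in both size and direction.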